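Swapping methyl for formyl on the ring nitrogen

The source may report more compounds than this note shows. Statements on the series, on what has been measured and on what is new or still open speak of the compounds shown alone.

Among the compounds with values here, in an ADME assay on Caco-2 cells (Homo sapiens) for permeability, in the apical to basolateral direction, at pH 7.4 (on this read-out lower numbers stand for lower permeability and higher numbers for higher permeability), compound 1 (`O=C(N[C@H]1CN(S(=O)(=O)c2ccccc2)C[C@@H]1C(=O)N1C[C@H]2CCNC[C@H]21)c1cc(-c2ccccc2Cl)on1`) gives 0.53 10^-6 cm/s while compound 2 (`CN1CCC[C@H](NC(=O)[C@H]2CN(S(=O)(=O)c3ccccc3)C[C@@H]2NC(=O)c2cc(-c3ccccc3Cl)on2)C1`) gives 1.3 10^-6 cm/s as the higher of the two numbers so far. Compound 3 (`O=CN1CCC[C@H](NC(=O)[C@H]2CN(S(=O)(=O)c3ccccc3)C[C@@H]2NC(=O)c2cc(-c3ccccc3Cl)on2)C1`) differs from compound 2 in one place, with formyl in place of methyl on an amine nitrogen in a ring. No measurement covers this exact swap. Within the data shown here, the only measured step (a 2.5-fold higher number from compound 1 to compound 2 (0.39 log units; beyond the scatter)) replaces a whole amine group on a carbonyl carbon and is modest, so it serves only as a rough guide to size. On that guide, a modest upward step is expected in this assay with real doubt about its direction. The estimated step (a 1.9-fold higher number from compound 2 to compound 3 (0.28 log units; within the scatter)) is therefore small. Compound 3 is expected at 2.5 10^-6 cm/s with an estimated range from 0.8 10^-6 cm/s to 8 10^-6 cm/s on this read-out.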

Compound 3, apparent permeability in the Caco-2 assay: 0.96 10^-6 cm/s
Compound 3: middle estimate off by 2.6-fold (0.42 log units), on the high side; the measured number falls inside the stated range.
By their numbers in the Caco-2 assay, from the lowest: compounds 1, 3 and 2 (each within the scatter of the next, the first and the last beyond it).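

In the Caco-2 assay, formyl in place of methyl on this ring nitrogen gives a 1.4-fold lower number from compound 2 to compound 3 (0.13 log units; within the scatter), and the larger change on the carbonyl carbon gives a 1.8-fold higher number from compound 1 to compound 3 (0.26 log units; within the scatter), so neither step separates the compounds it joins. The same swap at the ring nitrogen stands out far more clearly in a physicochemical assay for solubility, at pH 7.4 (a higher number here means a more soluble compound, a lower number a less soluble compound), with a 110-fold lower number from compound 2 to compound 3 (2.05 log units; beyond the scatter). In the physicochemical assay compound 2 gives 503000 nM and compound 3 gives 4500 nM. This is the first sign that the group on this nitrogen matters: formyl brings a large loss of solubility with no readable shift in permeability: the measured solubility of compound 2, 503000 nM, and of compound 3, 4500 nM, a 110-fold lower number (2.05 log units; beyond the scatter)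

From the compounds shown here alone, whether another group on this ring nitrogen, such as ethyl or acetyl, would stay closer to the solubility of compound 2 remains open. Which feature of formyl lies behind the drop also remains open, as only this one swap at this place is shown.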